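Changing One Aryl Ring: Expectation for Compound 3

The source may report more compounds than this note shows. Statements on the series, on what has been measured and on what is new or still open speak of the compounds shown alone.

In a functional assay on MCF7 cells (Homo sapiens) for cytotoxicity, read by CCK-8 assay, with a stated time of 72 h (a lower number here means a stronger inhibitor, a higher number a weaker inhibitor), compound 1 `C=CCn1c(=O)/c(=C\c2ccc(Cl)c(Cl)c2)[nH]c(=O)/c1=C\c1ccccc1` is reported as "not active" (no number reported), with no number attached. Among the compounds with values here, compound 2 `C=CCn1c(=O)/c(=C\c2cc(F)ccc2C)[nH]c(=O)/c1=C\c1ccccc1OC` gives 3100 nM in this assay, which makes it the only compound here with a measured number; the other entry carries no number at all. Compound 3 `C=CCn1c(=O)/c(=C\c2ccc(C)cc2)[nH]c(=O)/c1=C\c1ccccc1OC` has not yet been tested. It differs from compound 2 in one place: 4-methylphenyl in place of 5-fluoro-2-methylphenyl on a double-bonded chain carbon bound to an aromatic carbon. Within the data shown here, no measured pair in this set differs in only one place, so there is no step of known size to lean on. Among the measured compounds shown here, the change is expected to move the value in this assay only a little, if at all, since nothing among the measured compounds speaks for a large shift in either direction. The step from compound 2 to compound 3 is estimated at a 1.3-fold higher number from compound 2 to compound 3 (0.11 log units; within the scatter). Compound 3 is therefore expected to reach about 4000 nM, with a likely range from 1500 nM to 12000 nM.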

Compound 3, half-maximal inhibitory concentration: "not active" (no number reported)
No number was reported for compound 3; the estimate stays without a comparison.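

Within the data shown here, compound 3 carries no number in this assay, so no step from compound 2 to compound 3 can be read. The compounds shown leave open how far replacing 5-fluoro-2-methylphenyl with 4-methylphenyl shifts the value. No measured property bears on this result.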